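A few compounds are considered here, and "the series" means these few. Any claim that something is new, unique, unknown or untested is made for them only; others in the source may bear on it.

Measured in a functional assay (aorta) for inhibition, with Oryctolagus cuniculus as the target; on this read-out lower numbers stand for stronger inhibition and higher numbers for weaker inhibition:
- compound 1 `CCCCC1=NC2(CCCC2)C(=O)N1Cc1ccc(-c2ccccc2-c2noc(O)n2)cc1`: 2.6 nM
- compound 2 `CCCCC1=NC2(CCCC2)C(=O)N1Cc1ccc(-c2ccccc2-n2oc(=O)[nH]c2=O)cc1`: 2.8 nM
- compound 3 `CCCCC1=NC2(CCCC2)C(=O)N1Cc1ccc(-c2ccccc2C2=NOC(=O)C2)cc1`: 140 nM

Compound 3 is the weakest inhibitor of this set, with the highest of the three numbers at 140 nM. The next compound, compound 4 `CCCCC1=NC2(CCCC2)C(=O)N1Cc1ccc(-c2ccccc2-c2nnc(O)o2)cc1`, keeps the shared core and swaps only the group on an aromatic carbon: a group of 6 heavy atoms (2 carbon, 2 nitrogen, 2 oxygen; one five-membered aromatic ring with 3 hetero atoms) in place of a group of 6 heavy atoms (3 carbon, 1 nitrogen, 2 oxygen; one five-membered non-aromatic ring with 2 hetero atoms), on an aromatic carbon. The incoming 5-hydroxy-1,3,4-oxadiazol-2-yl group is a five-membered aromatic ring, whereas the group it replaces is non-aromatic.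

Two measured steps make the same kind of exchange in reverse, going from an aromatic ring to the non-aromatic one. They are a 54-fold higher number from compound 1 to compound 3 (1.73 log units; beyond the scatter) and a 50-fold higher number from compound 2 to compound 3 (1.70 log units; beyond the scatter), and both are large. The two aromatic groups themselves differ little, with a 1.1-fold higher number from compound 1 to compound 2 (0.03 log units; within the scatter). Three compounds make a thin basis, however, and none of them carries the ring of compound 4, so a full return to their level is not assured.

A large step towards a lower number is therefore expected, though probably slightly smaller than the two measured ones. The expected change is a 14-fold lower number from compound 3 to compound 4 (1.15 log units; beyond the scatter). For compound 4 the estimated value is 10 nM, with an expected range from 2.5 nM to 50 nM.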

Compound 4, half-maximal inhibitory concentration: 67 nM
For compound 4 the middle estimate is 6.7-fold (0.83 log units) below the measured one, and the stated range ends below it.
By their numbers in this assay, from the lowest: compounds 1 and 2 (each within the scatter of the next); then compound 4; then compound 3.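

The new result shows that, on this aromatic carbon ortho to a large group, a five-membered aromatic ring does not by itself bring back the low numbers of compounds 1 and 2. In this assay the exchange of the non-aromatic ring for 5-hydroxy-1,3,4-oxadiazol-2-yl gives only (a 2.1-fold lower number from compound 3 to compound 4 (0.32 log units; beyond the scatter)), while compound 4 remains far from both stronger compounds (compared with the first, a 26-fold higher number from compound 1 to compound 4 (1.41 log units; beyond the scatter); compared with the second, a 24-fold higher number from compound 2 to compound 4 (1.38 log units; beyond the scatter)). Compounds 1 and 4 carry rings with the same counts of carbon, nitrogen and oxygen, so the arrangement of those atoms within the ring makes a large difference here, though nothing available explains why.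

The compounds shown leave open whether a carboxylic acid or a tetrazole ring on this same aromatic carbon would give a number nearer to that of compounds 1 and 2 or nearer to that of compound 4. They also leave open whether the gap between compounds 1 and 4 would persist if the butyl chain on the shared core gave way to a propyl chain.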